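A Bulky Tail in Place of a Small Ring

A few compounds are considered here, and "the series" means these few. Any claim that something is new, unique, unknown or untested is made for them only; others in the source may bear on it.

Compound 1, `Cc1nc(NC2CCCC2)c2cc[nH]c2n1`, gives 72400000 nM in a functional assay on the whole organism for inhibition, with Nicotiana tabacum as the target; a lower number here means a stronger inhibitor, a higher number a weaker inhibitor.
Compound 2, `Cc1nc(NCCCO)c2cc[nH]c2n1`, gives 17800000 nM.
Compound 3, `Cc1nc(NCC2CC2)c2cc[nH]c2n1`, gives 77600000 nM.

Compound 3 holds the highest number of the three. Against compound 1 the gap is small: a 1.1-fold higher number from compound 1 to compound 3 (0.03 log units; within the scatter), so the two cannot be told apart on these numbers. Against compound 2 the difference is clearer: a 4.4-fold higher number from compound 2 to compound 3 (0.64 log units; beyond the scatter).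

Compound 4 is `Cc1nc(NCC(C)(C)C)c2cc[nH]c2n1`. It differs from compound 3 in one place: tert-butyl in place of cyclopropyl on a saturated chain carbon bound to a nitrogen on an aromatic ring. Within the data shown here, two measured steps bear on this. The step of a 1.1-fold higher number from compound 1 to compound 3 (0.03 log units; within the scatter) swaps one hydrocarbon group for another on the same nitrogen and shows no change beyond the scatter. The step of a 4.4-fold higher number from compound 2 to compound 3 (0.64 log units; beyond the scatter) involves a hydroxyl group that neither compound 3 nor compound 4 carries, so it says less about the present change. With only hydrocarbon groups exchanged, the expectation for compound 4 in this assay is a step no larger than the scatter: a 1.0-fold higher number from compound 3 to compound 4 (0.01 log units; within the scatter). Compound 4 is therefore estimated at about 80000000 nM, with a range from 30000000 nM to 200000000 nM.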

Compound 4, half-maximal inhibitory concentration: 200000000 nM
Beside the measured number, compound 4's estimate is 2.5-fold (0.40 log units) below it, within the range that was stated.
By their numbers in this assay, from the lowest: compound 2; then compounds 1 and 3 (each within the scatter of the next); then compound 4.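

In this assay, putting tert-butyl in place of cyclopropyl gives a 2.6-fold higher number from compound 3 to compound 4 (0.41 log units; beyond the scatter), the first sign that exchanging one hydrocarbon group for another at this position can move the number beyond the scatter. Neopentyl in place of cyclopentyl on the same nitrogen points the same way, with a 2.8-fold higher number from compound 1 to compound 4 (0.44 log units; beyond the scatter), so the hydrocarbon groups here do not all behave alike, even though compounds 1 and 3 could not be told apart. Against the 3-hydroxypropyl group of compound 2, the gap is now the widest in the set, at an 11-fold higher number from compound 2 to compound 4 (1.05 log units; beyond the scatter), and the steps printed from compound 4 to all the others make it the weakest inhibitor of the four.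

Nothing measured here explains why the neopentyl compound gives the highest number, so the cause of these steps remains unknown. From the compounds shown here alone, it also remains open whether a longer chain would raise or lower the number, and whether an amine or a carboxylic acid in place of the hydroxyl group of compound 2 would keep that compound's lower number or lose it.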